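Amino in Place of Fluoro: From Compound 1 to Compound 4

The source may hold more compounds than are shown below. What is called first, only, known or untested is meant among the compounds shown, and "the series" means these compounds.

Compound 1 `COC(=O)c1ccc(NCc2cncn2Cc2cccc(F)c2)cc1-c1ccccc1` has been examined in a toxicity assay on NIH3T3 cells (Mus musculus) for cytotoxicity, read by resazurin assay; a lower number here means that less compound is needed, a higher number that more compound is needed for the effect. In this assay compound 1 reaches only a limit, > 1000 nM, so no number is known for it. Two further compounds stand beside it. Compound 2 `O=[N+]([O-])c1ccc(Cn2cncc2CNc2cccc(-c3ccccc3)c2)cc1` gives 10000 nM in this assay. Compound 3 `CC(=O)c1ccc(NCc2cncn2Cc2ccc(-c3ccccc3)cc2)cc1-c1ccccc1` likewise reaches only a limit in this assay, > 10000 nM. Compound 1 thus sits at the limit of > 1000 nM in this assay, at which 1 of the 3 values shown sits, and compound 3 at the limit of > 10000 nM in this assay, at which 1 of the 3 values shown sits. No pair among these three differs in a single place, so no measured step can be read from them.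

Compound 4 `COC(=O)c1ccc(NCc2cncn2Cc2cccc(N)c2)cc1-c1ccccc1` differs from compound 1 by amino in place of fluoro on an aromatic carbon. With every measured value sitting at a limit or at a high number, and compound 1 itself reporting only the limit > 1000 nM, the change is expected to move compound 4 little if at all. The expected step, a step that the limit leaves unreadable from compound 1 to compound 4, would stay within the usual scatter. Compound 4 is therefore estimated at 10000 nM, within a range from 2000 nM to 30000 nM, and it may well come back as a limit once more.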

Compound 4, half-maximal effective concentration: > 10000 nM
Compound 4: no number, only a limit (the forecaster's own chance of this, stated with the estimate: 75%); the middle value lies on the limit itself.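

Compound 1 and compound 4 both report only limits in this assay, so no step can be read between them for amino in place of fluoro. The compounds shown leave open whether this change moves the value at all, and in which direction.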